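The compounds below may be only part of what the source reports. "The series", "measured", "known", "first", "only" and "open" are said of these compounds alone.

Measured compounds:
Compound 1 `C[C@@H](O[C@H]1CN2C(=O)C=C(c3ccc(C#N)cc3)CC2[C@@H]1c1ccc(F)cc1)c1cc(C(F)(F)F)cc(C(F)(F)F)c1`: 53 nM
Compound 2 `C[C@@H](O[C@H]1CN2C(=O)C=C(c3ccc(NS(C)(=O)=O)cc3)CC2[C@@H]1c1ccc(F)cc1)c1cc(C(F)(F)F)cc(C(F)(F)F)c1`: 54 nM
Compound 3 `Cc1cc(C2=CC(=O)N3C[C@H](O[C@H](C)c4cc(C(F)(F)F)cc(C(F)(F)F)c4)[C@@H](c4ccc(F)cc4)C3C2)ccn1`: 34 nM

All three share one core and differ only in the aryl group attached to a double-bonded ring carbon. In an assay on CHO cells for displacement of a labelled ligand from Substance-P receptor (Homo sapiens), in the presence of a further agent that is not named here (a lower number here means a stronger inhibitor, a higher number a weaker inhibitor), compound 3 gives 34 nM. Its distance from the others is small: a 1.6-fold lower number from compound 1 to compound 3 (0.19 log units; within the scatter) and a 1.6-fold lower number from compound 2 to compound 3 (0.20 log units; within the scatter), so compound 3 sits in the same range as compound 1 and compound 2 rather than apart from them.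

Compound 4 `COc1cc(C2=CC(=O)N3C[C@H](O[C@H](C)c4cc(C(F)(F)F)cc(C(F)(F)F)c4)[C@@H](c4ccc(F)cc4)C3C2)ccn1` keeps the pyridine of compound 3 and alters one substituent on it: methoxy in place of methyl on an aromatic carbon. Among the compounds with values here, no measured pair here exchanges a methyl for a methoxy, so no step speaks directly to this change. The steps that exist, a 1.0-fold higher number from compound 1 to compound 2 (0.01 log units; within the scatter), a 1.6-fold lower number from compound 1 to compound 3 (0.19 log units; within the scatter) and a 1.6-fold lower number from compound 2 to compound 3 (0.20 log units; within the scatter), all swap far larger pieces of that aryl group and still stay within the scatter, which suggests this region tolerates variation without a clear shift in this assay. The change from compound 3 to compound 4 is smaller still, so the expected step is a 1.1-fold higher number from compound 3 to compound 4 (0.05 log units; within the scatter), that is, none beyond the scatter.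

Compound 4 is therefore estimated at 38 nM in this assay, with a likely range from 15 nM to 95 nM.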

Compound 4, half-maximal inhibitory concentration: 44 nM
Estimate against measurement, compound 4: 1.2-fold (0.06 log units) below; measured number inside the range.
By their numbers in this assay, from the lowest: compounds 3, 4, 1 and 2 (each within the scatter of the next).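

In this assay, within the data shown here, the exchange of methyl for methoxy on the aromatic carbon next to the ring nitrogen gives a 1.3-fold higher number from compound 3 to compound 4 (0.11 log units; within the scatter) and so provides the first direct reading of this change: adding an oxygen atom and a hydrogen-bond acceptor here produces no shift beyond the scatter. The new group also stays in the range of the two phenyl-based groups, with a 1.2-fold lower number from compound 1 to compound 4 (0.08 log units; within the scatter) and a 1.2-fold lower number from compound 2 to compound 4 (0.09 log units; within the scatter) showing that 2-methoxypyridin-4-yl cannot be separated from either 4-cyanophenyl or 4-(methanesulfonamido)phenyl in this assay. No measurement here bears on why these four compounds sit so close together.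

The compounds shown leave open whether this tolerance extends beyond methyl and methoxy on the pyridine, for example to a dimethylamino group, a carboxylic acid or a longer chain such as butoxy. They also leave open whether an aryl group is needed at this double-bonded ring carbon at all, since a simple hydrogen or a saturated group such as morpholine would test that directly.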